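From Hydroxy to Methoxy: One Small Change

The source may hold more compounds than are shown below. What is called first, only, known or untested is meant among the compounds shown, and "the series" means these compounds.

In an ADME assay on HEK293 cells (Homo sapiens) for cytotoxicity, read by reporter gene assay and resazurin assay, with a stated time of 48 h (on this read-out higher numbers stand for lower toxicity in this test and lower numbers for higher toxicity in this test), compound 1 `COc1c(Br)cccc1C(=O)Nc1ccccc1` gives > 100000 nM, which is a limit of the assay and not a number. Within the data shown here, compound 2 `O=C(Nc1cccc(Cl)c1)c1cccc(Br)c1O` gives 32000 nM, the only true number so far. Compound 3 `COc1c(Br)cccc1C(=O)Nc1cccc(Cl)c1` differs from compound 2 at one place: methyl in place of hydrogen on an oxygen on an aromatic ring, turning hydroxy to methoxy. Among the measured compounds shown here, no measured pair shows this change alone. Compound 1 also carries a methoxy and stands at the limit > 100000 nM, so a modest shift toward lower toxicity in this assay is expected. The expected step is a 1.9-fold higher number from compound 2 to compound 3 (0.27 log units; within the scatter). For compound 3 the estimate is 60000 nM, with an expected range of 25000 nM to 100000 nM.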

Compound 3, half-maximal cytotoxic concentration: > 100000 nM
Compound 3: only a limit was reported; the forecaster's own chance of this, stated with the estimate: 40%; middle value at least 1.6-fold (0.22 log units) away from the limit.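

In this assay, among these compounds, methyl in place of hydrogen on the oxygen gives an at least 3.1-fold higher number from compound 2 to compound 3 (0.49 log units; beyond the scatter), the first readable step for this change, and it points toward lower toxicity in this test. The value of compound 3 is a limit and not a number, so this step gives only the smallest size the change could have: the limit of > 100000 nM in this assay, at which 2 of the 3 values shown sit. The step for chloro in place of hydrogen cannot be read, as compound 1 and compound 3 both stand at limits.

On these data alone, what a longer chain on this oxygen, or an amine in place of the hydroxy, would do in this assay remains open.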